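The compounds below may be only part of what the source reports. "The series", "measured", "known", "first", "only" and "open" are said of these compounds alone.

Measured so far:
compound 1, `O=C(NCc1cn(Cc2ccc(Cl)cc2)nn1)c1cn(-c2ccccc2)nc1-c1ccc(F)cc1`, 280 nM in a functional assay on MIA PaCa-2 cells (Homo sapiens) for antiproliferative activity, read by sulforhodamine B assay, with a stated time of 48 h; on this read-out lower numbers stand for stronger inhibition of growth and higher numbers for weaker inhibition of growth;
compound 2, `COc1ccc(Cn2cc(CNC(=O)c3cn(-c4ccccc4)nc3-c3ccc(F)cc3)nn2)cc1`, 3700 nM;
compound 3, `O=C(NCc1cn(Cc2ccc(F)cc2)nn1)c1cn(-c2ccccc2)nc1-c1ccc(Cl)cc1`, 1990 nM.

Compound 1 and compound 2 differ in one place, (methoxy in place of chloro on an aromatic carbon), and this gives a 13-fold higher number from compound 1 to compound 2 (1.12 log units; beyond the scatter). Compound 3 has the same atoms as compound 1, joined differently; how the two cores differ is not broken down here. Compound 3 stands near compound 2 and apart from compound 1, as the two values show.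

Compound 4, `COc1ccc(-c2nn(-c3ccccc3)cc2C(=O)NCc2cn(Cc3ccc(F)cc3)nn2)cc1`, is not yet measured. It differs from compound 3 in one place, (methoxy in place of chloro on an aromatic carbon). Within the data shown here, this is the same change as the one from compound 1 to compound 2, in the same place, on an aromatic carbon of a six-membered aromatic ring of carbon only, para to a large group; read one bond further out, from compound 3 to compound 4 it is 4-chlorophenyl to 4-methoxyphenyl only, whereas from compound 1 to compound 2 it reads also 4-chlorobenzyl to 4-methoxybenzyl, so the ring that carries it is not the same one in the two pairs.

Among the measured compounds shown here, the only step of this kind on record is large, and the expectation for compound 4 in this assay rests on it, tempered because a 13-fold higher number from compound 1 to compound 2 (1.12 log units; beyond the scatter) concerns a different ring of the molecule. A step of a 4.0-fold higher number from compound 3 to compound 4 (0.60 log units; beyond the scatter) is expected, and compound 4 is estimated at 8000 nM, between 2500 nM and 25000 nM.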

Compound 4, concentration for 50% growth inhibition: 24100 nM
Compound 4: the middle estimate sits 3.0-fold (0.48 log units) below what was measured; measured number inside the range.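

In this assay, among these compounds, methoxy in place of chloro on the 4-chlorophenyl ring gives a 12-fold higher number from compound 3 to compound 4 (1.08 log units; beyond the scatter), weaker growth inhibition of about the same size as the one seen when the same exchange is made on the benzyl ring of the other pair: the same change on two cores in this assay, a 13-fold higher number (1.12 log units; beyond the scatter) from compound 1 to compound 2 and a 12-fold higher number (1.08 log units; beyond the scatter) from compound 3 to compound 4, 1.1-fold (0.04 log units) apart, within the scatter of two such steps Across these two pairs, the exchange therefore carries over from one core to the other with no difference in size beyond the scatter, even though the ring that bears it is not the same one, and in both pairs the chloro compound is the one with the lower number. This does not show a general rule: it rests on two pairs, on a single exchange at a single kind of place, and with a halogen on the other aryl ring in each case, and it gives no reason for the loss of activity.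

From the compounds shown here alone, whether other groups at that aromatic carbon, such as ethoxy, hydroxy, an amine or a carboxylic acid, would give a step of similar size remains open. Also open, going by these compounds, is whether the unsubstituted phenyl group shared by all four compounds would tolerate the same exchange, and whether methoxy on both rings at once would add up.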